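This account rests on a few compounds, and the source may have more. Where it says the series, first, only, none or still open, it means among the compounds named here.

Of the compounds shown here, three on the shared core have been measured. In a functional assay on MDA-MB-468 cells (Homo sapiens) for antiproliferative activity (on this read-out lower numbers stand for stronger inhibition of growth and higher numbers for weaker inhibition of growth), compound 1 `COc1ccc(-c2nc3cc(F)ccc3s2)cc1` gives 330 nM, and compound 2 `COc1ccc(-c2nc3cc(F)ccc3s2)cc1Br` gives 420 nM. Compound 3 `COc1ccc(-c2nc3cc(F)ccc3s2)cc1OC` gives < 0.1 nM, which is a limit of the assay and not a number. This places compound 3 at the limit of < 0.1 nM in this assay, at which 1 of the 3 values shown sits, well ahead of the other two.

Compound 4 `COc1ccc(-c2nc3cc(F)ccc3s2)c(OC)c1OC` differs from compound 3 by one change: methoxy in place of hydrogen on an aromatic carbon. The new methoxy stands ortho to a large group, ortho to a methoxy group and meta to a methoxy group.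

Among the measured compounds shown here, the closest precedent is the same kind of change on a different aromatic carbon, an at least 3300-fold lower number from compound 1 to compound 3 (3.51 log units; beyond the scatter). Bromo gave no such effect, as shown by a 1.3-fold higher number from compound 1 to compound 2 (0.10 log units; within the scatter), while an at least 4200-fold lower number from compound 2 to compound 3 (3.62 log units; beyond the scatter) shows how much the choice of group mattered. These steps show that this ring can be highly sensitive to a single substituent, but they do not show what a further methoxy will do. Compound 3 also leaves no measurable room for a stronger result, so any number that can be read should lie on the weaker side. The expected change is an at least 200-fold higher number from compound 3 to compound 4 (2.30 log units; beyond the scatter), a clear loss but with wide uncertainty.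

For compound 4 the estimate is 20 nM, with an expected range from 0.1 nM to 2000 nM.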

Compound 4, concentration for 50% growth inhibition: 120 nM
For compound 4 the middle estimate is 6.0-fold (0.78 log units) below the measured one; the range from low to high includes it.
By their numbers in this assay, from the lowest: compound 4; then compounds 1 and 2 (each within the scatter of the next). At a limit, below all of these: compound 3.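

In this assay, a methoxy group put onto one aromatic carbon gave an at least 3300-fold lower number from compound 1 to compound 3 (3.51 log units; beyond the scatter), while the same change on another carbon, ortho to a large group, ortho to a methoxy group and meta to a methoxy group, gave an at least 1200-fold higher number from compound 3 to compound 4 (3.07 log units; beyond the scatter). The two steps run in opposite directions, so among these compounds a methoxy does not bring a gain wherever it is placed, and its outcome depends on which carbon carries it. The second step can be given only as a minimum and not as an exact size, because compound 3 carries a limit of the assay and not a number: the limit of < 0.1 nM in this assay, at which 1 of the 4 values shown sits.

Going by these compounds, it remains open whether the loss belongs to methoxy itself or to any group on this carbon, which a smaller hydroxy group or an amine in the same place on compound 3 could help to settle. On these data alone, it is also open how much depends on the two methoxy groups already present, a question that a single methoxy on this carbon of the core of compound 1 would address.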